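Cytotoxicity notes: furan analogue of compound 3

The compounds below may be only part of what the source reports. "The series", "measured", "known", "first", "only" and "open" are said of these compounds alone.

Compound 1 `C[C@H]1[C@H](NCc2cncs2)C[C@H]2C[C@@H]1C2(C)C` and compound 2 `C[C@H]1[C@H](NCc2cncnc2)C[C@H]2C[C@@H]1C2(C)C` share their core with compound 3 `C[C@H]1[C@H](NCc2ccc(Cl)s2)C[C@H]2C[C@@H]1C2(C)C`. In an ADME assay on MDCK cells (Canis lupus familiaris) for cytotoxicity, read by microscopy, with a stated time of 48 h (a higher number here means that more compound is tolerated, a lower number that less compound is tolerated), compound 1 gives > 100000 nM, a limit of the assay rather than a number. Compound 2 likewise gives > 100000 nM, again a limit. Going by the values given here, compound 3 gives 25000 nM, the only number in the set, and stands lowest: an at least 4.0-fold lower number from compound 1 to compound 3 (0.60 log units; beyond the scatter) and an at least 4.0-fold lower number from compound 2 to compound 3 (0.60 log units; beyond the scatter), both beyond the scatter, whereas a step that the two limits leave unreadable from compound 1 to compound 2. Compound 4 `C[C@H]1[C@H](NCc2ccco2)C[C@H]2C[C@@H]1C2(C)C` differs from compound 3 by furan-2-yl in place of 5-chlorothiophen-2-yl on a saturated chain carbon bound to an amine nitrogen. Both readable steps mark the 5-chlorothiophen-2-yl compound as the one tolerated least, so removing that group is expected to raise the number, with a 3.2-fold higher number from compound 3 to compound 4 (0.51 log units; beyond the scatter) estimated. Compound 4 is therefore expected to give about 80000 nM, within 25000 nM to 200000 nM, possibly reaching the limit (the limit of > 100000 nM in this assay, at which 2 of the 3 values shown sit).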

Compound 4, minimum cytotoxic concentration: 50000 nM
Beside the measured number, compound 4's estimate is 1.6-fold (0.20 log units) above it, within the range that was stated.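

In this assay, furan-2-yl in place of 5-chlorothiophen-2-yl gives a 2.0-fold higher number from compound 3 to compound 4 (0.30 log units; within the scatter), so the 5-chlorothiophen-2-yl compound no longer stands alone at the low end of the series. Against pyrimidin-5-yl and 1,3-thiazol-5-yl, the readings are only floors: an at least 2.0-fold lower number from compound 2 to compound 4 (0.30 log units; that floor lies within the scatter) and an at least 2.0-fold lower number from compound 1 to compound 4 (0.30 log units; that floor lies within the scatter), so compound 4 is not clearly separated from either. The upper end remains unresolved: the limit of > 100000 nM in this assay, at which 2 of the 4 values shown sit.

The compounds shown leave open how a thiophen-2-yl without chlorine or a 5-chlorofuran-2-yl would read on this saturated chain carbon, and therefore whether the chlorine or the ring sulfur matters here.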